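Swapping Fluoro for Chloro on Two Cores

The source may report more compounds than this note shows. Statements on the series, on what has been measured and on what is new or still open speak of the compounds shown alone.

Two pairs of compounds share one small change. Compound 1, `COc1cc(/C=C2\CN(C)C/C(=C\c3ccc(F)cc3)C2=O)cc(OC)c1OC`, and compound 2, `COc1cc(/C=C2\CN(C)C/C(=C\c3ccc(Cl)cc3)C2=O)cc(OC)c1OC`, differ only in that (chloro in place of fluoro on an aromatic carbon). In a functional assay on HepG2 cells (Homo sapiens) for cytotoxicity, read by MTT assay, with a stated time of 24 h (a higher number here means a weaker inhibitor, a lower number a stronger inhibitor), compound 1 gives 7340 nM, and compound 2 gives 8250 nM; the step between them is a 1.1-fold higher number from compound 1 to compound 2 (0.05 log units; within the scatter). The two numbers cannot be told apart there.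

Compound 3, `CN1C/C(=C\c2ccc(F)cc2)C(=O)/C(=C/c2cccc([N+](=O)[O-])c2)C1`, carries a different core; how its core differs from that of compound 1 is not broken down here. In this assay compound 3 gives 9340 nM, a number that sits within the scatter of both compound 1 and compound 2.

Compound 4, `CN1C/C(=C\c2ccc(Cl)cc2)C(=O)/C(=C/c2cccc([N+](=O)[O-])c2)C1`, has not been measured. It differs from compound 3 in that (chloro in place of fluoro on an aromatic carbon). Among the measured compounds shown here, the place of the change is described in the same words for both pairs, so this is the same change as the one from compound 1 to compound 2, made on a second core. Because the measured step of a 1.1-fold higher number from compound 1 to compound 2 (0.05 log units; within the scatter) stayed within the scatter, compound 4 is expected to show a step of a 1.1-fold higher number from compound 3 to compound 4 (0.03 log units; within the scatter), again small. The estimate for compound 4 in this assay is 10000 nM, expected to fall between 6000 nM and 17000 nM. For the measured compounds named here, the range is wide: only one earlier example of this change is available, and it sits on a different core.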

Compound 4, half-maximal inhibitory concentration: 8210 nM
Compound 4: the middle estimate sits 1.2-fold (0.09 log units) above what was measured, and the stated range covers the measured number.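

In this assay, swapping fluoro for chloro on the second core gives a 1.1-fold lower number from compound 3 to compound 4 (0.06 log units; within the scatter), so the numbers for the two compounds cannot be told apart, just as on the first core. Set side by side, the two steps do not differ: the same change on two cores in this assay, a 1.1-fold higher number (0.05 log units; within the scatter) from compound 1 to compound 2 and a 1.1-fold lower number (0.06 log units; within the scatter) from compound 3 to compound 4, 1.3-fold (0.11 log units) apart, within the scatter of two such steps. This shows that the 4-fluorophenyl to 4-chlorophenyl change behaved alike on these two cores, in that it gave no readable step on either one, but it does not show that the change has a real effect of any size, and a step lost in the scatter has no reliable direction to carry from one core to another.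

The compounds shown leave open whether a different group at this place, such as an amine, a carboxylic acid or a longer carbon chain, would give a step that stands clear of the scatter, and whether such a step would then carry over between the two cores. They also leave open whether the swap of fluoro for chloro would stay this small on a third core or on other cells.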